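This account rests on a few compounds, and the source may have more. Where it says the series, first, only, none or still open, it means among the compounds named here.

Compound 1 (`COc1cc(C=C2C(=O)N(c3ccc(Cl)cc3)N(c3ccc(Cl)cc3)C2=O)ccc1O`), compound 2 (`COc1cccc(C=C2C(=O)N(c3ccc(Cl)cc3)N(c3ccc(Cl)cc3)C2=O)c1O`) and compound 3 (`O=C1C(=Cc2cccc(Cl)c2)C(=O)N(c2ccc(Cl)cc2)N1c1ccc(Cl)cc1`) share one core and differ only in the group on a double-bonded chain carbon bound to a double-bonded ring carbon. In a functional assay on MGC-803 cells (Homo sapiens) for cytotoxicity, read by MTT assay, with a stated time of 72 h (on this read-out higher numbers stand for weaker inhibition and lower numbers for stronger inhibition), compound 1 gives 21800 nM, compound 2 gives 24300 nM and compound 3 gives 14400 nM, which places compound 3 within the scatter of both others.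

Compound 4 (`O=C1C(=Cc2ccc(Cl)cc2Cl)C(=O)N(c2ccc(Cl)cc2)N1c1ccc(Cl)cc1`) carries 2,4-dichlorophenyl in place of 3-chlorophenyl at that same place: 2,4-dichlorophenyl in place of 3-chlorophenyl on a double-bonded chain carbon bound to a double-bonded ring carbon.

Three measured steps changed this place, and all lie within the scatter: a 1.5-fold lower number from compound 1 to compound 3 (0.18 log units; within the scatter), a 1.7-fold lower number from compound 2 to compound 3 (0.23 log units; within the scatter) and a 1.1-fold higher number from compound 1 to compound 2 (0.05 log units; within the scatter). So far, exchanging this group has produced no clear shift among these three compounds. However, none of these steps shows the effect of adding a second chlorine, so this evidence is only indirect.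

The expected change is a 1.2-fold lower number from compound 3 to compound 4 (0.08 log units; within the scatter), which means no step beyond the scatter is expected in this assay. For compound 4 the estimate is 12000 nM, with an expected range of 5000 nM to 28000 nM.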

Compound 4, half-maximal inhibitory concentration: > 128000 nM
Compound 4 gave a limit, no number; the forecaster's own chance of this, stated with the estimate: 3%; at least 10-fold (1.02 log units) between middle value and limit.
By their numbers in this assay, from the lowest: compounds 3, 1 and 2 (each within the scatter of the next). At a limit, above all of these: compound 4.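

Compound 4 gave only a limit, not a number: the limit of > 128000 nM in this assay, at which 1 of the 4 values shown sits. Within the data shown here, this is the first exchange at this place, on a double-bonded chain carbon bound to a double-bonded ring carbon, to go beyond the scatter in this assay: 2,4-dichlorophenyl in place of 3-chlorophenyl gives an at least 8.8-fold higher number from compound 3 to compound 4 (0.94 log units; beyond the scatter). The other two steps point the same way, with an at least 5.2-fold higher number from compound 2 to compound 4 (0.72 log units; beyond the scatter) and an at least 5.8-fold higher number from compound 1 to compound 4 (0.76 log units; beyond the scatter), so this place does not accept every group equally, and inhibition weakens clearly with 2,4-dichlorophenyl.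

The compounds shown cannot separate the effect of having a second chlorine from that of the altered chlorine pattern on the ring. On these data alone, it also remains open what a 4-chlorophenyl, a 2-chlorophenyl or an aminophenyl group would give at this place.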